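Lengthening the Vinyl Group on a Weak Inhibitor

This account rests on a few compounds, and the source may have more. Where it says the series, first, only, none or still open, it means among the compounds named here.

Two related compounds have been measured so far in a functional assay on A549 cells (Homo sapiens) for inhibition, read by MTT assay, with a stated time of 72 h (a lower number here means a stronger inhibitor, a higher number a weaker inhibitor), on these cells. Compound 1 (`CC/C=C\C(=O)Nc1cc(Nc2nc3c(c(-c4cn(C)c5ccccc45)n2)CSCC3)c(OC)cc1N(C)CCN(C)C`) gives 236 nM and compound 2 (`C=CC(=O)Nc1cc(Nc2nc3c(c(-c4cn(C)c5ccccc45)n2)CS(=O)(=O)CC3)c(OC)cc1N(C)CCN(C)C`) gives 8690 nM as its reading. Compound 2 therefore has the higher of the two numbers, by a gap beyond the usual scatter, and is the weaker inhibitor of the pair.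

Compound 3 (`CCC/C=C\C(=O)Nc1cc(Nc2nc3c(c(-c4cn(C)c5ccccc45)n2)CS(=O)(=O)CC3)c(OC)cc1N(C)CCN(C)C`) carries pent-1-en-1-yl in place of vinyl on a carbonyl carbon. Within the data shown here, no measured pair shows this change alone. Compound 1 also has a chain longer than vinyl on that carbonyl and reads 236 nM in this assay as well, but it differs from compound 2 in the core too, so it offers only a weak hint towards a lower number. The expected step (a 1.4-fold lower number from compound 2 to compound 3 (0.16 log units; within the scatter)) is therefore small and is not expected to go beyond the scatter. In this assay the estimate for compound 3 is 6000 nM with a range of 2000 nM to 18000 nM around it.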

Compound 3, half-maximal inhibitory concentration: 57 nM
Compound 3: middle estimate off by 110-fold (2.02 log units), on the high side, and the stated range ends above it.
By their numbers in this assay, from the lowest: compound 3; then compound 1; then compound 2.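

In this assay, among these compounds, vinyl and pent-1-en-1-yl on a carbonyl carbon are the only difference within this pair, and that exchange brings a 150-fold lower number from compound 2 to compound 3 (2.18 log units; beyond the scatter), a large step beyond the usual scatter. The earlier compounds shown here gave only a weak hint about this position, since the two of them also differ in the core, whereas this pair shows that the group on the carbonyl alone can shift the reading by this much. It also shows that the core shared by compound 2 and compound 3 is not tied to a weak reading, as the group on the carbonyl decides a great deal on this core. Nothing measured here explains why the longer group gives so much lower a number.

Going by these compounds, a single step cannot show how the reading depends on the chain, so it stays open whether a shorter prop-1-en-1-yl, a longer hept-1-en-1-yl, a saturated pentyl or a chain ending in a dimethylamino group would read like compound 3 or like compound 2. On these data alone, it is also open whether the same exchange would have a step of similar size on the core of compound 1.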